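The source may report more compounds than this note shows. Statements on the series, on what has been measured and on what is new or still open speak of the compounds shown alone.

Compound 1 `Cc1ccsc1/C=C(/SCc1ccc(Cl)cc1)C(=O)c1ccc(Cl)cc1`: 50000 nM
Compound 2 `Cc1ccsc1/C=C(/SCc1ccc(Cl)c(Cl)c1)C(=O)c1ccc(Cl)cc1`: 50000 nM

In a functional assay on DU-145 cells (Homo sapiens) for inhibition, read by trypan blue exclusion, with a stated time of 96 h (a lower number here means a stronger inhibitor of growth, a higher number a weaker inhibitor of growth), compound 1 gives 50000 nM, level with compound 2. Compound 3 `O=C(/C(=C\c1ccc(Br)cc1)SCc1ccc(Cl)cc1)c1ccc(Cl)cc1` keeps the rest of compound 1 and exchanges one group: 4-bromophenyl in place of 3-methylthiophen-2-yl on a double-bonded chain carbon bound to a double-bonded chain carbon. Within the data shown here, the only measured step, no change at the digits printed from compound 1 to compound 2 (within the scatter), is a chloro in place of hydrogen at a different place, so it offers little guidance for this exchange. Among the measured compounds shown here, with no measured step at this place, a modest move toward stronger inhibition is expected, though only tentatively. The estimate for compound 3 is 20000 nM, with an expected range from 2500 nM to 60000 nM. This estimate means an expected 2.5-fold lower number from compound 1 to compound 3 (0.40 log units; beyond the scatter).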

Compound 3, concentration for 50% growth inhibition: 1000 nM
Compound 3: middle estimate off by 20-fold (1.30 log units), on the high side; the whole stated range lies above it.
By their numbers in this assay, from the lowest: compound 3; then compounds 1 and 2 (each within the scatter of the next).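

In this assay, exchanging the group on a double-bonded chain carbon bound to a double-bonded chain carbon gives a 50-fold lower number from compound 1 to compound 3 (1.70 log units; beyond the scatter) for 4-bromophenyl in place of 3-methylthiophen-2-yl. The earlier chloro step elsewhere in the molecule gave no movement, so this is the first place shown where a single change shifts growth inhibition. Nothing available explains the shift.

Open, as far as these compounds go, is whether the bromine or the six-membered carbon ring accounts for it. A plain phenyl group at this place would separate the two.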